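Adding a methoxy to compound 2

The compounds below may be only part of what the source reports. "The series", "measured", "known", "first", "only" and "open" are said of these compounds alone.

In a functional assay on 786-0 cells (Homo sapiens) for inhibition, read by sulforhodamine B assay, with a stated time of 48 h (on this read-out lower numbers stand for stronger inhibition of growth and higher numbers for weaker inhibition of growth), two compounds with the same core have been measured so far. Compound 2 (`COc1ccc(/C=C/C2(C)C=CC(=O)O2)cc1OC`) gives 22900 nM and holds the lower of the two numbers. Compound 1 (`COc1ccc(/C=C/C2(C)C=CC(=O)O2)c(OC)c1`) gives 108000 nM as the higher number, and the gap between them lies beyond the usual scatter of repeated measurements. The next compound to be read is compound 3 (`COc1ccc(/C=C/C2(C)C=CC(=O)O2)c(OC)c1OC`), which differs from compound 2 by methoxy in place of hydrogen on an aromatic carbon. For the measured compounds named here, no step between measured compounds shows what such a change does in this assay, so the expectation rests on thin ground. Going by the values given here, the only guide is the spread of the two values, with compound 1 at 108000 nM marking how high a number this small series has reached. A modest rise is expected, meaning weaker inhibition of growth, although a step in the other direction cannot be excluded. The estimated step is a 1.7-fold higher number from compound 2 to compound 3 (0.24 log units; within the scatter) on this reading. Compound 3 is expected at 40000 nM with an estimated range from 12000 nM to 120000 nM in this read-out.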

Compound 3, concentration for total growth inhibition: 132000 nM
Estimate against measurement, compound 3: 3.3-fold (0.52 log units) below; measured number outside the range, above it.
By their numbers in this assay, from the lowest: compound 2; then compounds 1 and 3 (each within the scatter of the next).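

In this assay, methoxy in place of hydrogen on the aromatic carbon ortho to the group of 9 heavy atoms now has a measured cost: a 5.8-fold higher number from compound 2 to compound 3 (0.76 log units; beyond the scatter), so at this position the change goes with weaker inhibition of growth. The same named change gives a different result when made on compound 1, where a 1.2-fold higher number from compound 1 to compound 3 (0.09 log units; within the scatter), so in these two steps its outcome depends on the compound that receives it, and the third methoxy of compound 3 brings no readable difference from compound 1. Nothing shown here explains why the two steps differ.

From the compounds shown here alone, only hydrogen and methoxy have been seen on this aromatic carbon, so it remains unknown whether the loss of inhibition in compound 3 is specific to methoxy or would also appear with a smaller fluorine atom, a hydroxyl group or an amine there. The two steps also leave open how a longer chain, such as ethoxy, would read on the same carbon, and whether any group at this position could bring the number below that of compound 2 at 22900 nM.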